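Replacing Methyl With a Hydroxymethyl-Thiazole on a Fused Core

The source may hold more compounds than are shown below. What is called first, only, known or untested is meant among the compounds shown, and "the series" means these compounds.

Measured compounds:
compound 1 `CC(C)(C)c1ccc2c(N)c(C#N)c(N)nc2n1`: 14200 nM
compound 2 `N#Cc1c(N)nc2nc(C3CCCC3)ncc2c1N`: 89000 nM
compound 3 `Cc1nc(C(C)(C)C)nc2nc(N)c(C#N)c(N)c12`: 37000 nM

In a physicochemical assay for solubility, in phosphate buffer, with a stated time of 18 h (on this read-out higher numbers stand for higher solubility and lower numbers for lower solubility), compound 3 stands second highest of the three numbers. Its nearest neighbour is compound 2, whose number is higher by a gap beyond the usual scatter, and its furthest is compound 1, whose number is lower, also beyond the scatter.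

Compound 4 `CC(C)(C)c1nc(-c2nc(CO)cs2)c2c(N)c(C#N)c(N)nc2n1` has not yet been measured. It differs from compound 3 in one place: 4-(hydroxymethyl)-1,3-thiazol-2-yl in place of methyl on an aromatic carbon. A small group leaves and a larger one with its own ring enters, with one hydrogen-bond donor and three acceptors.

Among the compounds with values here, no step between two measured compounds matches this change, so the expectation rests on the size of the change alone. A step downward in this assay of a size beyond the scatter is expected, estimated at a 2.5-fold lower number from compound 3 to compound 4 (0.39 log units; beyond the scatter).

For compound 4 the expected value in this assay is 15000 nM, within a range from 4000 nM to 50000 nM.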

Compound 4, solubility: < 1000 nM
Compound 4 was reported as a limit; the forecaster's own chance of this, stated with the estimate: 5%; middle value at least 15-fold (1.17 log units) away from the limit.
By their numbers in this assay, from the lowest: compound 1; then compound 3; then compound 2. At a limit, below all of these: compound 4.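

In this assay, compound 4 is reported only as a limit, < 1000 nM. Within the data shown here, putting 4-(hydroxymethyl)-1,3-thiazol-2-yl in place of methyl on this aromatic carbon, next to the ring nitrogen, gives an at least 37-fold lower number from compound 3 to compound 4 (1.56 log units; beyond the scatter), a large step that shows this one position can change the read-out strongly, something the earlier compounds, which had no single-place comparison, could not show. Only one side of the step's size is known, and the result sits at the end of the range reported: the limit of < 1000 nM in this assay, at which 1 of the 4 values shown sits.

The compounds shown leave open whether the fall goes with the thiazole ring itself, with the hydroxymethyl group on it, or simply with the larger size of what enters. An ethyl chain, a phenyl ring, or a thiazole ring carrying an amine or a carboxylic acid at this place would help separate these.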